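Cyclopropyl Ring Closure on a Fluorinated Urea Acid

The compounds below may be only part of what the source reports. "The series", "measured", "known", "first", "only" and "open" are said of these compounds alone.

Compound 1 `CC(C)(NC(=O)Nc1ccc(F)c(C(F)(F)F)c1)C(=O)O`: < 7 uL/min
Compound 2 `O=C(O)CNC(=O)Nc1ccc(F)c(C(F)(F)F)c1`: < 7 uL/min

Two urea acids sharing one aryl core have been measured. In an ADME assay on microsomes from liver (Mus musculus) for metabolic stability, using NADPH, with a stated time of 60 min (on this read-out lower numbers stand for slow clearance and higher numbers for fast clearance), compound 1 gives < 7 uL/min, which is a limit of the assay rather than a number. In this assay compound 2 gives < 7 uL/min, likewise a limit. The step that the two limits leave unreadable from compound 1 to compound 2 therefore cannot be read, since the limit of < 7 uL/min in this assay, at which 2 of the 2 values shown sit, holds both values. Compound 2 thus stands at the floor of what this assay reports, with no numeric value to rank it against compound 1.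

Compound 3 `O=C(Nc1ccc(F)c(C(F)(F)F)c1)NC1(C(=O)O)CC1` has not yet been measured. It differs from compound 2 by 1-carboxycyclopropyl in place of carboxymethyl on an amide-type nitrogen. Among the compounds with values here, no measured step gives a readable size, so the only evidence bearing on this change is the limit of < 7 uL/min in this assay, at which 2 of the 2 values shown sit, under which both measured compounds sit. Compound 3 is therefore expected to remain at or near that limit in this assay, with an estimated value of 5 uL/min spanning 1 uL/min to 12 uL/min. The step expected here, a step that the limit leaves unreadable from compound 2 to compound 3, lies within the scatter.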

Compound 3, intrinsic clearance in a liver preparation (reported as CLH), per the amount of preparation that the assay uses: < 7 uL/min
Compound 3: only a limit was reported; the forecaster's own chance of this, stated with the estimate: 75%; the middle value lies beyond the limit too.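

In this assay compound 3 gives < 7 uL/min as a limit of the assay and not a number. No new step can be read among compound 1, compound 2 and compound 3, since all three sit at one limit: the limit of < 7 uL/min in this assay, at which 3 of the 3 values shown sit. The compounds shown leave open how far apart these three lie in this assay and whether any group on the amide-type nitrogen would give a readable number.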